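A few compounds are considered here, and "the series" means these few. Any claim that something is new, unique, unknown or untested is made for them only; others in the source may bear on it.

Working notes on the series. Compound 1 `Nc1ncnc2c1ccn2COCCO` is the parent of the set, the core carrying a (2-hydroxyethoxy)methyl group on the ring nitrogen and a free amino group. In an ADME assay (Fibroblast) for cytotoxicity, with Homo sapiens as the target (on this read-out higher numbers stand for weaker inhibition and lower numbers for stronger inhibition), compound 1 gives > 100000 nM, which is a limit of the assay and not a number. Compound 2 `CC(=O)OCCOCn1cc(C#N)c2c(N)ncnc21` is a further member; in this assay compound 2 gives > 100000 nM, likewise a limit. Compound 3 `N#Cc1cnc2n(COCCO)cnc(N)c1-2` belongs to the same set, and in this assay compound 3 gives > 320000 nM, again a limit. Compound 1 thus stands among three results that are all limits, sitting at the limit of > 100000 nM in this assay, at which 2 of the 3 values shown sit, while the third sits at the limit of > 320000 nM in this assay, at which 1 of the 3 values shown sits. Among the compounds with values here, no step between measured compounds can be read from these numbers, since none of them is an actual value.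

Compound 4 `NC(=O)c1cn(COCCO)c2ncnc(N)c12` differs from compound 1 by carbamoyl in place of hydrogen on an aromatic carbon. Given that nothing in the set has yet produced a number in this assay, the expected step is none beyond the scatter, with no direction. The expected step of a number no higher from compound 1 to compound 4 (the limit leaves the size open) accordingly rests on the limits alone. Compound 4 is expected to come out at 100000 nM, within 50000 nM to 320000 nM, and most probably to be reported as a limit once more.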

Compound 4, half-maximal inhibitory concentration: > 320000 nM
Compound 4 was reported as a limit; the forecaster's own chance of this, stated with the estimate: 85%; middle value at least 3.2-fold (0.50 log units) away from the limit.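

Within the data shown here, compound 1 and compound 4 both stand as limits of the assay in this assay, not as numbers, and no step between them can be read. The compounds shown leave open whether carbamoyl in place of hydrogen on an aromatic carbon changes the read-out at all, and none of the four results gives an actual value in this assay.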